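Propargylsulfanyl to propylsulfanyl on a triazolopyrimidine hydrazone

The source may hold more compounds than are shown below. What is called first, only, known or untested is meant among the compounds shown, and "the series" means these compounds.

Of the compounds shown here, three that share a common core have been tested in a functional assay on MCF7 cells (Homo sapiens) for antiproliferative activity, read by MTT assay, with a stated time of 72 h; on this read-out lower numbers stand for stronger inhibition and higher numbers for weaker inhibition. Compound 1, `CCCSc1nc(N/N=C/c2cccnc2)c2nnn(Cc3ccccc3)c2n1`, gives 58700 nM. Compound 2, `CCCSc1nc(N/N=C(\C)c2ccc(OC)cc2)c2nnn(Cc3ccccc3)c2n1`, reaches only the limit of the measurement, > 64000 nM, which is a boundary of this assay and not a number (the limit of > 64000 nM in this assay, at which 1 of the 3 values shown sits). Compound 3, `C#CCSc1nc(N/N=C(\C)c2ccccc2O)c2nnn(Cc3ccccc3)c2n1`, gives 11300 nM, the lowest of the two numbers reported; the value of compound 1 stands higher, beyond the usual scatter.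

Compound 4, `CCCSc1nc(N/N=C(\C)c2ccccc2O)c2nnn(Cc3ccccc3)c2n1`, is not yet measured in this assay. It differs from compound 3 in one place: ethyl in place of ethynyl on a saturated chain carbon bound to a sulfur. Within the data shown here, compounds 1 and 2 also carry the propylsulfanyl group, but they differ from compound 4 elsewhere as well, so no single step among the measured compounds isolates this change. Compound 4 is expected to show a moderate rise in its number, a step of a 1.9-fold higher number from compound 3 to compound 4 (0.29 log units; within the scatter) from the value of compound 3. Compound 4 is therefore estimated at 22000 nM, within a range of 7000 nM to 64000 nM.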

Compound 4, half-maximal inhibitory concentration: 11000 nM
Estimate against measurement, compound 4: 2.0-fold (0.30 log units) above, and the stated range covers the measured number.
By their numbers in this assay, from the lowest: compounds 4 and 3 (each within the scatter of the next); then compound 1. At a limit, above all of these: compound 2.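

In this assay the change from propargylsulfanyl to propylsulfanyl, with the rest of the structure fixed, gives a 1.0-fold lower number from compound 3 to compound 4 (0.01 log units; within the scatter) and so the triple bond can be lost with no change beyond the scatter. With propylsulfanyl held constant, 2-hydroxyphenyl in place of 4-methoxyphenyl gives an at least 5.8-fold lower number from compound 2 to compound 4 (0.76 log units; beyond the scatter) and the exchange of the larger group on the nitrogen on an aromatic ring gives a 5.3-fold lower number from compound 1 to compound 4 (0.73 log units; beyond the scatter) so among these compounds the steps beyond the scatter come with the aromatic end and not with the sulfur chain. Compound 2, the start of the first of those two steps, stands at a limit and not at a number: the limit of > 64000 nM in this assay, at which 1 of the 4 values shown sits.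

As far as these compounds go, whether this tolerance extends to a longer chain or a chain ending in an amine on the sulfur remains open. Also open, from the compounds shown here alone, is whether it holds when the 2-hydroxyphenyl group is replaced.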